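Benzyl to Phenoxy on the Carbonyl-Bound Chain Carbon

The source may report more compounds than this note shows. Statements on the series, on what has been measured and on what is new or still open speak of the compounds shown alone.

For the measured compounds named here, in an assay for binding affinity to Adrenergic receptor alpha-1 (Rattus norvegicus) (a higher number here means a weaker inhibitor, a lower number a stronger inhibitor), compound 2 `COc1cc2nc(N3CCN(C(=O)CCc4ccccc4)CC3)nc(N)c2cc1OC` gives 3.39 nM, the lowest of the two numbers measured so far. Compound 1 `COc1cc2nc(N3CCN(C(=O)/C=C/c4cccc(F)c4)CC3)nc(N)c2cc1OC` gives 20.9 nM, and the step shows a 6.2-fold lower number from compound 1 to compound 2 (0.79 log units; beyond the scatter). Compound 3 `COc1cc2nc(N3CCN(C(=O)COc4ccccc4)CC3)nc(N)c2cc1OC` differs from compound 2 by phenoxy in place of benzyl on a saturated chain carbon bound to a carbonyl carbon. Going by the values given here, the only measured step, from compound 1 to compound 2, altered a different part of the chain, so it bears on this change only loosely, showing that alterations at the carbonyl-linked chain can move the number modestly. A modest shift is therefore expected, with no confident direction. Compound 3 is estimated at 5.5 nM, within 1.5 nM to 20 nM. The expected step is a 1.6-fold higher number from compound 2 to compound 3 (0.21 log units; within the scatter).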

Compound 3, half-maximal inhibitory concentration: 12.6 nM
Compound 3: the middle estimate sits 2.3-fold (0.36 log units) below what was measured; measured number inside the range.
By their numbers in this assay, from the lowest: compound 2; then compounds 3 and 1 (each within the scatter of the next).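

In this assay, phenoxy in place of benzyl on a saturated chain carbon bound to a carbonyl carbon gives a 3.7-fold higher number from compound 2 to compound 3 (0.57 log units; beyond the scatter) and shows that the number here responds to a single chain atom, carbon or oxygen, even with the aromatic ring kept. The remaining new step is a 1.7-fold lower number from compound 1 to compound 3 (0.22 log units; within the scatter) and so leaves those two compounds indistinguishable. No evidence at hand explains why the number moved.

Still open, on these data alone, is how a sulfur in place of the phenoxy oxygen, or an amine nitrogen there, would compare. As far as these compounds go, a longer chain between the carbonyl and the ring is equally open.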